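The source may hold more compounds than are shown below. What is called first, only, known or untested is meant among the compounds shown, and "the series" means these compounds.

Compound 1 `CC(=O)OCc1ccc2oc(=O)c(C(=O)Nc3cccc(Cl)c3)cc2c1` gives 66.9% in a functional assay on HT-1080 cells (Homo sapiens), read by transwell migration, with a stated time of 24 h, tested at 1 uM; on this read-out lower numbers stand for a stronger effect and higher numbers for a weaker effect at the one concentration tested. Compound 2 `O=C(Oc1cccc(F)c1)c1cc2cc([N+](=O)[O-])ccc2oc1=O` gives 53.6%, and compound 3 `NCc1ccc2oc(=O)c(C(=O)Oc3cccc(F)c3)cc2c1` gives 45.3% in this assay. Compound 3 thus sits within the scatter of compound 2, while the gap to compound 1 is beyond the scatter. Among the compounds with values here, the only measured step, a number 8.3 percentage points lower from compound 2 to compound 3 (within the scatter), changes a different group and does not bear on the change now considered. Compound 4 `NCc1ccc2oc(=O)c(C(=O)Oc3cccc(I)c3)cc2c1` differs from compound 3 by iodo in place of fluoro on an aromatic carbon. Within the data shown here, no measured pair shows what an iodo in place of a fluoro does here, so no step beyond the scatter is expected in this assay; the expected step is a number 0.3 percentage points lower from compound 3 to compound 4 (within the scatter). Compound 4 is therefore estimated at 45%, within 30% to 60%.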

Compound 4, a percentage reported as activity, at one concentration (the size of the read-out at that concentration, not a potency): 25.3%
Compound 4: middle estimate off by 19.7 percentage points, on the high side; the measured number lies below the stated range.
By their numbers in this assay, from the lowest: compound 4; then compounds 3 and 2 (each within the scatter of the next); then compound 1.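

In this assay, the change from 3-fluorophenyl to 3-iodophenyl gives a number 20 percentage points lower from compound 3 to compound 4 (beyond the scatter), so the read-out responds to the group at this place on the aromatic ring. Among the compounds shown that differ in one place, this is the first step beyond the scatter, whereas the other such step, a number 8.3 percentage points lower from compound 2 to compound 3 (within the scatter), stayed within it. Nothing measured here accounts for the step.

From the compounds shown here alone, whether a bromo or a methyl at this place would also lower the number remains open. So does whether iodo would give a similar step alongside the nitro of compound 2.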